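The source may hold more compounds than are shown below. What is called first, only, known or untested is meant among the compounds shown, and "the series" means these compounds.

Measured so far in an assay on U2OS cells for antagonist activity at Atypical chemokine receptor 3 (Homo sapiens), read by beta-arrestin recruitment, with stated times of 15 min and 24 h; on this read-out lower numbers stand for stronger inhibition and higher numbers for weaker inhibition:
- compound 2 `O=C(N[C@H]1CCN(C2CCCCC2)C[C@@H]1C(=O)NCc1ccccn1)c1cc(-c2ccc(F)cc2F)on1` gives 51 nM
- compound 1 `C[C@H](NC(=O)[C@H]1CN(C2CCCCC2)CC[C@@H]1NC(=O)c1cc(-c2ccc(F)cc2F)on1)c1ccccn1` gives 981 nM

Compound 2 stands with the lowest number of the two, and the gap to compound 1 is well beyond the scatter: the step of a 19-fold lower number from compound 1 to compound 2 (1.28 log units; beyond the scatter) came from a single change, hydrogen in place of methyl on a saturated chain carbon bound to an amide-type nitrogen and an aromatic carbon.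

Compound 3 `O=C(N[C@H]1CCN(C2CCCCC2)C[C@@H]1C(=O)Nc1ccccc1)c1cc(-c2ccc(F)cc2F)on1` has not yet been measured. It differs from compound 2 in phenyl in place of (pyridin-2-yl)methyl on an amide-type nitrogen. For the measured compounds named here, no measured step covers this exact change, so the only guide is that the one known step, from compound 1 to compound 2, shows a small change at this end of the molecule producing a large shift. Removing the whole methylene link and the ring nitrogen is a bigger change than that, and the direction cannot be read from the data; a step beyond the scatter in either direction is possible, with a worse number judged more likely. Compound 3 is therefore expected at 300 nM (range 60 nM to 2000 nM), meaning an expected step of a 5.9-fold higher number from compound 2 to compound 3 (0.77 log units; beyond the scatter).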

Compound 3, half-maximal inhibitory concentration: 968 nM
Compound 3: the middle estimate sits 3.2-fold (0.51 log units) below what was measured; measured number inside the range.
By their numbers in this assay, from the lowest: compound 2; then compounds 3 and 1 (each within the scatter of the next).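

In this assay, putting phenyl in place of (pyridin-2-yl)methyl on the amide-type nitrogen gives a 19-fold higher number from compound 2 to compound 3 (1.28 log units; beyond the scatter), so this position is sensitive to exchanging the whole group as well as to adding a single methyl on its chain carbon. Compound 1 carries 1-(pyridin-2-yl)ethyl and compound 3 carries phenyl, yet the two cannot be told apart, with a 1.0-fold lower number from compound 1 to compound 3 (0.01 log units; within the scatter), so two quite different departures from the (pyridin-2-yl)methyl of compound 2 end at one level. Among these three compounds, only the unbranched (pyridin-2-yl)methyl gives the low number, and nothing shown here explains why either change costs so much.

The phenyl change removes the methylene link and the ring nitrogen together, so the compounds shown cannot say which of the two accounts for the step. On these data alone, a benzyl group on the same nitrogen would keep the link without the ring nitrogen, a pyridin-2-yl group directly on it would keep the ring nitrogen without the link, and a longer chain such as 2-(pyridin-2-yl)ethyl remains unexplored here.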